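From 4-methylphenyl to 2-chloro-6-methoxyphenyl on the shared core

The source may report more compounds than this note shows. Statements on the series, on what has been measured and on what is new or still open speak of the compounds shown alone.

In an ADME assay on microsomes from liver (Rattus norvegicus) for metabolic stability, read by LC-MS, using NADPH, at 37 degrees C (a higher number here means that the compound lasts longer, a lower number that the compound disappears faster), compound 3 `Cc1ccc(-c2nc(CN3CCC(C(=O)NCCCN4C[C@H](C)C[C@H](C)C4)CC3)c(C)o2)cc1` gives only a limit, > 0.5 h. Compound 1 `Cc1cc(C)c(-c2nc(CN3CCC(C(=O)NCCCN4C[C@H](C)C[C@H](C)C4)CC3)c(C)o2)c(C)c1` also gives only a limit, > 0.5 h. These two are joined by a step that the two limits leave unreadable from compound 1 to compound 3. Compound 2 `COc1cccc(Br)c1-c1nc(CN2CCC(C(=O)NCCCN3C[C@H](C)C[C@H](C)C3)CC2)c(C)o1` gives a number, 0.0583 h.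

Compound 4 `COc1cccc(Cl)c1-c1nc(CN2CCC(C(=O)NCCCN3C[C@H](C)C[C@H](C)C3)CC2)c(C)o1` differs from compound 3 by 2-chloro-6-methoxyphenyl in place of 4-methylphenyl on an aromatic carbon, with 2-chloro-6-methoxyphenyl in place of 4-methylphenyl on an aromatic carbon. The nearest measured comparison is an at least 8.5-fold higher number from compound 2 to compound 3 (0.93 log units; beyond the scatter), where compound 2 carries 2-bromo-6-methoxyphenyl in the place that holds 2-chloro-6-methoxyphenyl in compound 4. The same size appears in an at least 8.5-fold lower number from compound 1 to compound 2 (0.93 log units; beyond the scatter). Both sizes are only bounds, resting on (the limit of > 0.5 h in this assay, at which 2 of the 3 values shown sit).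

Compound 2 at 0.0583 h sets the direction, so a fall of at least modest size is expected in this assay. The estimated step is an at least 7.1-fold lower number from compound 3 to compound 4 (0.85 log units; beyond the scatter), a fall beyond the scatter. For compound 4 the estimated half-life is 0.07 h, with an expected range of 0.03 h to 0.2 h.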

Compound 4, half-life in the liver assay: 0.055 h
Compound 4: middle estimate off by 1.3-fold (0.10 log units), on the high side; the range from low to high includes it.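

In the liver assay compound 2 gives 0.0583 h, and this short half-life proves not to be peculiar to bromo: a 1.1-fold lower number from compound 2 to compound 4 (0.03 log units; within the scatter), so chloro and bromo on this methoxyphenyl cannot be told apart. Against the two phenyl groups that carry only methyl, the liver assay gives an at least 9.0-fold lower number from compound 3 to compound 4 (0.95 log units; beyond the scatter) and an at least 9.0-fold lower number from compound 1 to compound 4 (0.95 log units; beyond the scatter), so the gap seen for the bromo compound appears again with chloro. Both of these sizes are only bounds: the limit of > 0.5 h in the liver assay, at which 2 of the 4 values shown sit.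

In a physicochemical assay for solubility, in phosphate buffer, measured as kinetic solubility, at pH 7.4 (a higher number here means a more soluble compound, a lower number a less soluble compound), compound 3 gives > 69 ug/mL, which is a limit. In the physicochemical assay compound 4 gives > 76 ug/mL, which is also a limit. The step between these two compounds cannot be read. Going by these compounds, whether a phenyl carrying a methoxy group alone, or a chloro alone, would keep the short half-life or return to the limit stays open.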